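The source may report more compounds than this note shows. Statements on the series, on what has been measured and on what is new or still open speak of the compounds shown alone.

Working notes on the series.

Four compounds share a quinazoline-type core bearing a bromo-substituted anilino group, with two different linkers to a sulfonamide-bearing phenyl. Compound 1 is `COc1cc2ncnc(Nc3cccc(Br)c3)c2cc1OCCCCC(=O)Nc1ccc(S(N)(=O)=O)cc1` and compound 2 is `COc1cc2ncnc(Nc3ccc(F)c(Br)c3)c2cc1OCCCCC(=O)Nc1ccc(S(N)(=O)=O)cc1`; these two carry the longer, amide-containing linker. Compound 3 is `NS(=O)(=O)c1ccc(NC(=S)Nc2ccc3ncnc(Nc4ccc(F)c(Br)c4)c3c2)cc1` and compound 4 is `NS(=O)(=O)c1ccc(NC(=S)Nc2ccc3ncnc(Nc4cccc(Br)c4)c3c2)cc1`; these two carry the thiourea linker.

In a functional assay on A-431 cells (Homo sapiens) for antiproliferative activity, read by MTT assay, with a stated time of 72 h (on this read-out lower numbers stand for stronger inhibition and higher numbers for weaker inhibition), compound 1 gives 9750 nM and compound 2 gives 8020 nM. The two differ only by hydrogen in place of fluoro on an aromatic carbon, and this gives a 1.2-fold higher number from compound 2 to compound 1 (0.08 log units; within the scatter). In this assay compound 3 gives 18200 nM; the difference between the cores of compound 3 and compound 2 is not broken down here, and the two values are simply set side by side.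

Compound 4 has not been measured. It differs from compound 3 by hydrogen in place of fluoro on an aromatic carbon, the same change as from compound 2 to compound 1, at a place described in the same words. Because the earlier step was a 1.2-fold higher number from compound 2 to compound 1 (0.08 log units; within the scatter), compound 4 is expected to sit close to compound 3, and the estimated step is a 1.2-fold higher number from compound 3 to compound 4 (0.06 log units; within the scatter) in this assay. For compound 4 the estimate in this assay is 21000 nM, with the likely range running from 10000 nM to 42000 nM. This rests on a single prior instance of the change, so the range is kept wide.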

Compound 4, half-maximal inhibitory concentration: 20700 nM
Estimate against measurement, compound 4: 1.0-fold (0.01 log units) above; measured number inside the range.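

In this assay, the change from 3-bromo-4-fluorophenyl to 3-bromophenyl on the thiourea-linked compounds gives a 1.1-fold higher number from compound 3 to compound 4 (0.06 log units; within the scatter). Set beside the step on the amide-linked compounds, the change reads the same on both cores: the same change on two cores in this assay, a 1.2-fold higher number (0.08 log units; within the scatter) from compound 2 to compound 1 and a 1.1-fold higher number (0.06 log units; within the scatter) from compound 3 to compound 4, 1.1-fold (0.03 log units) apart, within the scatter of two such steps. This shows that, in these two pairs, the fluoro group can be replaced by hydrogen without a readable shift in this assay on either core, but since neither step rises above the scatter, it does not show that the change has any effect of its own, and two pairs say nothing about how it would behave on a further core.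

The compounds shown leave open what separates the two cores, since compound 2 and compound 3 differ in more than one place and their values cannot be assigned to the linker alone. Also open, going by these compounds, is whether a chloro group or an ethynyl group in place of the bromo group, a shorter chain in the amide-containing linker, or a carboxylic acid in place of the sulfonamide would move the numbers beyond the scatter.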